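A 2-fluorophenyl group replaces cyclopentyl in a cytotoxicity series

A few compounds are considered here, and "the series" means these few. Any claim that something is new, unique, unknown or untested is made for them only; others in the source may bear on it.

Of the compounds shown here, three sharing one core have been measured in a functional assay on HeLa cells (Homo sapiens) for cytotoxicity, read by WST assay, with a stated time of 48 h; on this read-out lower numbers stand for stronger inhibition and higher numbers for weaker inhibition. Compound 1 `Oc1ccccc1/C=C/C[C@H]1C[C@@H]([C@@H](O)c2ccccc2)CO[C@@H]1c1ccccc1` gives 21800 nM, compound 2 `O=[N+]([O-])c1cccc(/C=C/C[C@H]2C[C@@H]([C@@H](O)c3ccccc3)CO[C@@H]2c2ccccc2)c1` gives 7850 nM and compound 3 `O[C@@H](c1ccccc1)[C@H]1CO[C@H](c2ccccc2)[C@@H](C/C=C/C2CCCC2)C1` gives 9330 nM. The measured steps are a 2.8-fold lower number from compound 1 to compound 2 (0.44 log units; beyond the scatter), a 2.3-fold lower number from compound 1 to compound 3 (0.37 log units; beyond the scatter) and a 1.2-fold higher number from compound 2 to compound 3 (0.08 log units; within the scatter). Compound 3 therefore stands level with compound 2, and only compound 1 stands apart.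

Compound 4 `O[C@@H](c1ccccc1)[C@H]1CO[C@H](c2ccccc2)[C@@H](C/C=C/c2ccccc2F)C1` carries 2-fluorophenyl in place of cyclopentyl on a double-bonded chain carbon bound to a double-bonded chain carbon. All three measured steps were made at this same place, and none was more than modest. The two phenyl-bearing compounds mark the likely span: compound 2 at 7850 nM and compound 1 at 21800 nM. No step beyond the scatter is therefore expected, with any drift more likely upward. The expected change is a 1.2-fold higher number from compound 3 to compound 4 (0.07 log units; within the scatter). Compound 4 is estimated at 11000 nM, with an expected range from 5500 nM to 22000 nM.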

Compound 4, half-maximal inhibitory concentration: 9730 nM
Beside the measured number, compound 4's estimate is 1.1-fold (0.05 log units) above it; the measured number falls inside the stated range.
By their numbers in this assay, from the lowest: compounds 2, 3 and 4 (each within the scatter of the next); then compound 1.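

In this assay, an aromatic ring carrying fluorine at this place reads the same as the non-aromatic cyclopentyl ring (a 1.0-fold higher number from compound 3 to compound 4 (0.02 log units; within the scatter)), so swapping one ring type for the other at a double-bonded chain carbon does not by itself shift the number. Compound 4 is also level with the 3-nitrophenyl compound (a 1.2-fold higher number from compound 2 to compound 4 (0.09 log units; within the scatter)), which leaves compounds 2, 3 and 4 as one group despite their different rings. Going by these compounds alone, only compound 1 goes against this, and the single change of fluoro in place of hydroxy on an aromatic carbon separates it (a 2.2-fold lower number from compound 1 to compound 4 (0.35 log units; beyond the scatter)).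

No supporting data explain why the hydroxy compound stands apart. Still open, from the compounds shown here alone, is whether an amine, a carboxylic acid or a longer chain at this place would leave the number within this group or move it.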